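From cyclopropylmethyl to 4-fluorobenzyl on the shared core

The source may report more compounds than this note shows. Statements on the series, on what has been measured and on what is new or still open speak of the compounds shown alone.

Measured in a functional assay on A549 cells (Homo sapiens) for antiproliferative activity, read by MTT assay, with a stated time of 48 h; on this read-out lower numbers stand for stronger inhibition and higher numbers for weaker inhibition:
Compound 1 `Cn1cc(-c2cnc3ccnc(NC(=O)C4CC4)c3c2)cn1`: > 50000 nM (a limit of the assay, not a number)
Compound 2 `Cn1cc(-c2cnc3ccnc(NCC4CC4)c3c2)cn1`: 8900 nM

So far, compound 2 holds the only true number, 8900 nM. Compound 3 `Cn1cc(-c2cnc3ccnc(NCc4ccc(F)cc4)c3c2)cn1` keeps the shared core but has 4-fluorophenyl in place of cyclopropyl on a saturated chain carbon bound to a nitrogen on an aromatic ring. Among the compounds with values here, only one measured step touches this part of the molecule: an at least 5.6-fold lower number from compound 1 to compound 2 (0.74 log units; beyond the scatter). That step replaced a carbonyl-linked group, whereas the new change keeps the saturated chain carbon and alters only the group attached to it. Within the data shown here, it therefore offers weak guidance, and no measured step tests this swap directly. Only a small shift towards lower numbers is expected, probably within the scatter. The expected change is a 1.8-fold lower number from compound 2 to compound 3 (0.25 log units; within the scatter). For compound 3 the estimated value is 5000 nM, with an expected range of 1500 nM to 20000 nM.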

Compound 3, half-maximal inhibitory concentration: 5200 nM
Compound 3: middle estimate off by 1.0-fold (0.02 log units), on the low side; measured number inside the range.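

In this assay, 4-fluorophenyl in place of cyclopropyl on the saturated chain carbon gives a 1.7-fold lower number from compound 2 to compound 3 (0.23 log units; within the scatter), so compound 2 and compound 3 cannot be told apart, even though a three-membered ring of carbon gives way to a six-membered aromatic ring. Replacing cyclopropylcarbonyl with 4-fluorobenzyl gives an at least 9.6-fold lower number from compound 1 to compound 3 (0.98 log units; beyond the scatter), a second case alongside an at least 5.6-fold lower number from compound 1 to compound 2 (0.74 log units; beyond the scatter) in which the compound without the carbonyl gives the lower number. Compound 1 carries a limit of the assay, not a number, so the true size of both steps stays unknown: the limit of > 50000 nM in this assay, at which 1 of the 3 values shown sits.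

From the compounds shown here alone, whether any group on this saturated chain carbon can move the number beyond the scatter stays open, as only cyclopropyl and 4-fluorophenyl appear there. Plain phenyl would isolate the part played by the fluorine, while an amine or a longer chain would test a different kind of group at this place.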